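The source may hold more compounds than are shown below. What is called first, only, known or untested is meant among the compounds shown, and "the series" means these compounds.

Measured so far in a functional assay on the whole organism with Mus musculus as the target; on this read-out higher numbers stand for an effect only at larger amounts of compound and lower numbers for an effect already at smaller amounts:
Compound 1 `NC(=O)/C=C1\CCc2c(F)cccc21` gives > 100 mg/kg as a limit
Compound 2 `O=C(/C=C1\CCc2c(F)ccc(F)c21)NC1CC1` gives 59 mg/kg as a number

The value of compound 1 is a limit of the assay and not a number. Going by the values given here, compound 2 therefore holds the only actual number in this assay so far.

Compound 3 `NC(=O)/C=C1\CCc2c(F)ccc(F)c21` has hydrogen in place of cyclopropyl on an amide-type nitrogen of compound 2 (hydrogen in place of cyclopropyl on an amide-type nitrogen) and has yet to be measured. Among the compounds with values here, no measured pair shows this change on its own. A modest move toward larger doses is expected. This expectation rests on compound 1, which also has hydrogen on an amide-type nitrogen and whose > 100 mg/kg is a limit of the assay. The expected step is small, a 1.2-fold higher number from compound 2 to compound 3 (0.07 log units; within the scatter) and may not clear the usual scatter. The estimated value for compound 3 is 70 mg/kg with an expected range from 25 mg/kg to 170 mg/kg.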

Compound 3, dose for half-maximal effect: 56 mg/kg
Estimate against measurement, compound 3: 1.3-fold (0.10 log units) above; measured number inside the range.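

In this assay, hydrogen in place of cyclopropyl on the amide-type nitrogen gives a 1.1-fold lower number from compound 2 to compound 3 (0.02 log units; within the scatter), so this read-out does not tell the two groups apart at this position on the shared core. Compound 1 gives > 100 mg/kg, which is a limit of the assay and not a number. Fluoro in place of hydrogen on an aromatic carbon gives an at least 1.7-fold lower number from compound 1 to compound 3 (0.25 log units; that floor lies within the scatter), and the full size of this step cannot be read because one end of it is a limit: the limit of > 100 mg/kg in this assay, at which 1 of the 3 values shown sits.

From the compounds shown here alone, it remains open whether a longer chain, a phenyl ring or a hydroxyethyl group on the amide-type nitrogen would stand apart from hydrogen and cyclopropyl. Going by these compounds, it is equally open how chloro or methoxy would compare with fluoro on that aromatic carbon.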